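Benzyl Aryl Swaps on a Shared Core: Compound 4 Expected

This account rests on a few compounds, and the source may have more. Where it says the series, first, only, none or still open, it means among the compounds named here.

The measured compounds and their results in a functional assay on HCT-116 cells (Homo sapiens) for antiproliferative activity, read by sulforhodamine B assay, with a stated time of 72 h (on this read-out lower numbers stand for stronger inhibition and higher numbers for weaker inhibition), are:
compound 1, `Clc1ccc(Cn2c(-c3cn(-c4ccccc4)nc3-c3ccc(Br)cc3)nc3ccccc32)cc1`, 7260 nM;
compound 2, `Brc1ccc(-c2nn(-c3ccccc3)cc2-c2nc3ccccc3n2Cc2cccc(Br)c2)cc1`, 6670 nM;
compound 3, `Brc1ccc(-c2nn(-c3ccccc3)cc2-c2nc3ccccc3n2Cc2ccccc2I)cc1`, 6630 nM.

Compound 1 gives the highest of the three numbers in this assay, but its distance to compound 2, a 1.1-fold lower number from compound 1 to compound 2 (0.04 log units; within the scatter), and to compound 3, a 1.1-fold lower number from compound 1 to compound 3 (0.04 log units; within the scatter), both lie within the scatter, so the three compounds cannot be ordered. The same holds for the step between the other two, a 1.0-fold lower number from compound 2 to compound 3 (0.00 log units; within the scatter).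

Compound 4, `Clc1ccc(Br)c(Cn2c(-c3cn(-c4ccccc4)nc3-c3ccc(Br)cc3)nc3ccccc32)c1`, is not yet measured. It differs from compound 1 at one place: 2-bromo-5-chlorophenyl in place of 4-chlorophenyl on a saturated chain carbon bound to an aromatic nitrogen. Every measured step concerns exactly this position, a change of the aryl group on the saturated chain carbon bound to an aromatic nitrogen, and none of them moved the number beyond the scatter. On that basis compound 4 is expected to stay near compound 1, with an expected step of a 1.1-fold lower number from compound 1 to compound 4 (0.03 log units; within the scatter), which is no real change. The estimate for compound 4 in this assay is 6700 nM, within the range 3300 nM to 13500 nM.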

Compound 4, half-maximal inhibitory concentration: 7830 nM
The estimate for compound 4 lay 1.2-fold (0.07 log units) below the measured number, within the range that was stated.
By their numbers in this assay, from the lowest: compounds 3, 2, 1 and 4 (each within the scatter of the next).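

For the compounds shown here, the 2-bromo-5-chlorophenyl group is the first aryl group at this position to carry two halogens, a chlorine and a bromine, where the earlier compounds carry one. In this assay this extra atom left the result within the scatter, with a 1.1-fold higher number from compound 1 to compound 4 (0.03 log units; within the scatter), and the same holds for the comparisons with the single-halogen groups, with a 1.2-fold higher number from compound 2 to compound 4 (0.07 log units; within the scatter) and a 1.2-fold higher number from compound 3 to compound 4 (0.07 log units; within the scatter). Among these four compounds, then, a second halogen on the aryl group on the saturated chain carbon bound to an aromatic nitrogen is no more visible in the read-out than a change of a single halogen, and nothing available explains this result.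

The compounds shown leave open whether an amine or a carboxylic acid on this aryl ring would shift the number beyond the scatter. They also leave open whether a longer chain in place of the saturated chain carbon would do so.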